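Compound 3 to compound 4: ethynyl in place of nitro

This account rests on a few compounds, and the source may have more. Where it says the series, first, only, none or still open, it means among the compounds named here.

Measured so far in a functional assay on NCI-H1975 cells (Homo sapiens) for cytotoxicity, read by MTT assay, with a stated time of 72 h; on this read-out higher numbers stand for weaker inhibition and lower numbers for stronger inhibition
- compound 1 `c1ccc(Nc2ncc3nc(Nc4ccccc4)n(C4CCCC4)c3n2)cc1` gives > 10000 nM as a limit of the assay
- compound 2 `CC(=O)Nc1ccc(Nc2ncc3nc(Nc4ccccc4)n(C4CCCC4)c3n2)cc1` gives 1210 nM
- compound 3 `CN1CCN(c2ccc(Nc3ncc4nc(Nc5cccc([N+](=O)[O-])c5)n(C5CCCC5)c4n3)cc2)CC1` gives 980 nM

Within the data shown here, compound 3 with 980 nM and compound 2 with 1210 nM lie within the scatter of each other, and they are the only two numbers so far. The entry for compound 1 is the limit of > 10000 nM in this assay, at which 1 of the 3 values shown sits, and stays a limit.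

The next compound is compound 4 `C#Cc1cccc(Nc2nc3cnc(Nc4ccc(N5CCN(C)CC5)cc4)nc3n2C2CCCC2)c1`, which keeps everything in compound 3 except one group. The change is ethynyl in place of nitro on an aromatic carbon with ethynyl in place of nitro on an aromatic carbon, so that 3-nitrophenyl becomes 3-ethynylphenyl.

Among the measured compounds shown here, the only measured step is an at least 8.2-fold lower number from compound 1 to compound 2 (0.91 log units; beyond the scatter) and it lies beyond the scatter, with a limit at one end. For the measured compounds named here, that step is acetamido in place of hydrogen and does not touch the group changing here, so no measured step speaks directly to nitro or ethynyl.

With nothing to set a direction, the expectation stays close to compound 3 at 980 nM in this assay and carries a wide range. The expected step is a 1.2-fold lower number from compound 3 to compound 4 (0.09 log units; within the scatter) and is not expected to go beyond the scatter. For compound 4 the estimated value is 800 nM with an expected range from 200 nM to 3000 nM for this compound.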

Compound 4, half-maximal inhibitory concentration: 650 nM
Compound 4: middle estimate off by 1.2-fold (0.09 log units), on the high side; measured number inside the range.
By their numbers in this assay, from the lowest: compounds 4, 3 and 2 (each within the scatter of the next). At a limit, above all of these: compound 1.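

Among these compounds, replacing 3-nitrophenyl with 3-ethynylphenyl, with the rest of the structure held fixed, gives in this assay a first reading of this position on the (3-nitrophenyl)amino arm: a 1.5-fold lower number from compound 3 to compound 4 (0.18 log units; within the scatter) is the step, and it does not separate the two groups. This position therefore takes ethynyl in place of nitro without a shift beyond the scatter, even though nitro brings hydrogen-bond acceptors and ethynyl brings none, and a triple bond replaces the double bond outside the aromatic ring. Nothing measured for these compounds bears on why the two groups read alike in this assay, and the one limit in the series belongs to a compound that differs elsewhere.

Still open, on these data alone, is how far this tolerance extends: a primary amine, a carboxylic acid, a nitrile or a longer chain such as propynyl at this same position could fall in line with nitro and ethynyl or move the number well away from them, and a single pair of groups cannot settle that. Also open, as far as these compounds go, is whether ethynyl and nitro would still read alike on a different carbon of this aromatic ring, or with the remaining parts of the structure changed.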